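A few compounds are considered here, and "the series" means these few. Any claim that something is new, unique, unknown or untested is made for them only; others in the source may bear on it.

Measured compounds:
compound 1 `C=CC(=O)Nc1cc(Nc2ncc3ncn(-c4ccccc4)c3n2)c(OC)cc1N(C)CCN(C)C`: 8080 nM
compound 2 `C=CC(=O)Nc1cc(Nc2ncc3ncn(-c4ccc(C(C)C)cc4)c3n2)c(OC)cc1N(C)CCN(C)C`: 15300 nM
compound 3 `C=CC(=O)Nc1cc(Nc2ncc3ncn(-c4ccc(F)cc4)c3n2)c(OC)cc1N(C)CCN(C)C`: 12000 nM

All three share one core and differ only in the group on the aromatic ring. In an ADME assay on HT-29 cells (Homo sapiens) for cytotoxicity, read by MTT assay, with a stated time of 72 h (on this read-out lower numbers stand for stronger inhibition and higher numbers for weaker inhibition), compound 3 holds the second highest of the three numbers; its distance to the others is given by a 1.3-fold lower number from compound 2 to compound 3 (0.11 log units; within the scatter) and by a 1.5-fold higher number from compound 1 to compound 3 (0.17 log units; within the scatter), so the three numbers cannot be told apart.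

Compound 4 `C=CC(=O)Nc1cc(Nc2ncc3ncn(-c4ccc(Cl)cc4)c3n2)c(OC)cc1N(C)CCN(C)C` is the next member; its change from compound 3 is chloro in place of fluoro on an aromatic carbon. For the measured compounds named here, the steps that bear on this position are a 1.5-fold higher number from compound 1 to compound 3 (0.17 log units; within the scatter), a 1.3-fold lower number from compound 2 to compound 3 (0.11 log units; within the scatter) and a 1.9-fold higher number from compound 1 to compound 2 (0.28 log units; within the scatter): every substituent tried there so far has left this assay unmoved beyond the scatter, and no step beyond the scatter is therefore expected here either. Compound 4 is expected to give about 12000 nM, between 6000 nM and 24000 nM, which means an expected step of no change at the digits printed from compound 3 to compound 4 (within the scatter).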

Compound 4, half-maximal inhibitory concentration: 7690 nM
Compound 4: middle estimate off by 1.6-fold (0.19 log units), on the high side; measured number inside the range.
By their numbers in this assay, from the lowest: compounds 4, 1, 3 and 2 (each within the scatter of the next).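

In this assay, chloro joins hydrogen, fluoro and isopropyl as a fourth group at this place on the aromatic ring, and its steps to all three stay within the scatter (a 1.6-fold lower number from compound 3 to compound 4 (0.19 log units; within the scatter); a 2.0-fold lower number from compound 2 to compound 4 (0.30 log units; within the scatter); a 1.1-fold lower number from compound 1 to compound 4 (0.02 log units; within the scatter)). The change from fluoro to chloro therefore gives no readable difference between the two halogens, and the four compounds form one unresolved set. No supporting data on this result are available. Going by these compounds, whether an amine, a carboxylic acid or a longer chain here would give a step beyond the scatter stays open.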